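A Bare Triazole in Place of the Hydroxyphenyl Arm

The source may report more compounds than this note shows. Statements on the series, on what has been measured and on what is new or still open speak of the compounds shown alone.

compound 1 `O=C1O[C@H]([C@@H](O)Cn2cc(-c3cccc(O)c3)nn2)C(OCc2ccccc2)=C1OCc1ccccc1`: 42900 nM
compound 2 `CCCCCCCCCCc1cn(C[C@H](O)[C@H]2OC(=O)C(OCc3ccccc3)=C2OCc2ccccc2)nn1`: 28800 nM
compound 3 `COc1ccc(-c2cn(C[C@H](O)[C@H]3OC(=O)C(OCc4ccccc4)=C3OCc3ccccc3)nn2)cc1`: a limit, > 100000 nM

In a functional assay on HCT-116 cells (Homo sapiens) for antiproliferative activity, read by MTT assay, with a stated time of 72 h (on this read-out higher numbers stand for weaker inhibition and lower numbers for stronger inhibition), compound 1 gives 42900 nM, the higher of the two numbers measured; compound 2 sits nearest, a 1.5-fold lower number from compound 1 to compound 2 (0.17 log units; within the scatter). Compound 3 reached only (the limit of > 100000 nM in this assay, at which 1 of the 3 values shown sits). Compound 4 `O=C1O[C@H]([C@@H](O)Cn2ccnn2)C(OCc2ccccc2)=C1OCc1ccccc1` differs from compound 1 by hydrogen in place of 3-hydroxyphenyl on an aromatic carbon. The steps that speak to this change are a 1.5-fold lower number from compound 1 to compound 2 (0.17 log units; within the scatter) and an at least 2.3-fold higher number from compound 1 to compound 3 (0.36 log units; beyond the scatter): a long chain left the number where it was, while a different aryl pushed it to the limit. Compound 4 is therefore expected to give a modestly higher number in this assay, about 90000 nM (40000 nM to 200000 nM), an estimated step of a 2.1-fold higher number from compound 1 to compound 4 (0.32 log units; beyond the scatter).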

Compound 4, half-maximal inhibitory concentration: > 100000 nM
Compound 4: a limit, no number (the forecaster's own chance of this, stated with the estimate: 45%); at least 1.1-fold (0.04 log units) between middle value and limit.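

The change to hydrogen gives an at least 2.3-fold higher number from compound 1 to compound 4 (0.36 log units; beyond the scatter) and an at least 3.4-fold higher number from compound 2 to compound 4 (0.54 log units; beyond the scatter), so 3-hydroxyphenyl and decyl each go with a measured number that the bare position does not give. In this assay compound 4 stands at a limit and not a number, as compound 3 does: the limit of > 100000 nM in this assay, at which 2 of the 4 values shown sit. Compound 3 goes against any rule that a large group here is enough, and the step between compound 3 and compound 4 cannot be read.

As far as these compounds go, whether a shorter chain such as butyl, or a phenyl bearing an amine, would give a number on this carbon stays open.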